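The source may hold more compounds than are shown below. What is called first, only, known or untested is meant among the compounds shown, and "the series" means these compounds.

Compound 1 `Cc1ccc2c(NCc3ccc(NC(=O)C4CCN(Cc5ccc(Cl)cc5)CC4)cc3)nc(N(C)C)nc2c1` shows no measurable cytotoxicity: in a functional assay on SV5A8 cells (Homo sapiens) for cytotoxicity (on this read-out higher numbers stand for weaker inhibition and lower numbers for stronger inhibition), compound 1 gives > 3180 nM, which is a limit of the assay and not a number. Compound 2 `Cc1ccc2c(NCc3ccc(NC(=O)C4CCN(Cc5cccc(F)c5)CC4)cc3)nc(N(C)C)nc2c1` carries 3-fluorophenyl in place of 4-chlorophenyl on a saturated chain carbon bound to an amine nitrogen in a ring. In this assay compound 2 gives > 4170 nM, again a limit. The step that the two limits leave unreadable from compound 1 to compound 2 is therefore unreadable because both values sit at their limits the limit of > 3180 nM in this assay, at which 1 of the 2 values shown sits (the limit of > 4170 nM in this assay, at which 1 of the 2 values shown sits).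

Compound 3 `Cc1ccc2c(NCc3ccc(NC(=O)C4CCN(C(=O)OC(C)(C)C)CC4)cc3)nc(N(C)C)nc2c1` is not yet measured. Its change from compound 1 is tert-butoxycarbonyl in place of 4-chlorobenzyl on an amine nitrogen in a ring. Within the data shown here, no measured step bears on this change, and the single measured step cannot be read, so there is no basis for expecting a shift in either direction beyond the scatter. Compound 3 is expected to give 5000 nM in this assay, within 2000 nM to 20000 nM, most likely again as a limit. The step that the limit leaves unreadable from compound 1 to compound 3 is thus an estimate of essentially no change.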

Compound 3, half-maximal inhibitory concentration: > 4820 nM
Compound 3 ended at the assay's limit; the forecaster's own chance of this, stated with the estimate: 80%; the middle value lies beyond the limit too.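

In this assay compound 3 gives > 4820 nM, again a limit of the assay. The steps from compound 1 to compound 3 and from compound 2 to compound 3 cannot be read: all three values are limits. As far as these compounds go, whether the group on the amine nitrogen in a ring affects cytotoxicity at all remains open.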